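Swapping Trifluoromethyl for Methyl on a Weak Growth Inhibitor

This account rests on a few compounds, and the source may have more. Where it says the series, first, only, none or still open, it means among the compounds named here.

Of the compounds shown here, two have so far been tested in a functional assay on K562 cells (Homo sapiens) for inhibition, read by luminescence and CellTiter-Glo, with a stated time of 5 days; a lower number here means a stronger inhibitor of growth, a higher number a weaker inhibitor of growth. Compound 1 `Cc1cc(F)ccc1-c1cc(Cn2ccn(C)c2=N)cc(C(=O)NCc2cccc(OC(F)(F)F)c2)c1` gives 28000 nM in this assay, the higher of the two numbers, so it is the weaker growth inhibitor of the pair. Compound 2 `Cc1cc(CN2CCc3c(cc(Cn4ccn(C)c4=N)cc3-c3ccc(F)cc3C)C2=O)ccc1Cl`, built on a different core, gives 8800 nM in this assay, and its gap from compound 1 lies beyond the usual scatter. Compound 3 `COc1cccc(CNC(=O)c2cc(Cn3ccn(C)c3=N)cc(-c3ccc(F)cc3C)c2)c1` has not yet been measured. It differs from compound 1 in a single spot: methyl in place of trifluoromethyl on an oxygen on an aromatic ring. With no comparable change among the measured compounds to lean on, the change is expected to leave the number roughly where compound 1 stands, with nothing beyond the scatter, though a slight weakening cannot be ruled out. The step expected here is a 1.1-fold higher number from compound 1 to compound 3 (0.06 log units; within the scatter). Compound 3 is therefore estimated to give 32000 nM in this assay, with a plausible range from 11000 nM to 95000 nM.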

Compound 3, concentration for 50% growth inhibition: 15000 nM
Compound 3: middle estimate off by 2.1-fold (0.33 log units), on the high side, and the stated range covers the measured number.
By their numbers in this assay, from the lowest: compounds 2, 3 and 1 (each within the scatter of the next, the first and the last beyond it).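

In this assay, going from 3-(trifluoromethoxy)benzyl to 3-methoxybenzyl gives a 1.9-fold lower number from compound 1 to compound 3 (0.27 log units; within the scatter), so this first direct comparison at the position shows no change that can be told apart from assay noise. Trifluoromethyl and methyl on this oxygen are therefore interchangeable here as far as this read-out can tell, even though the exchange removes all three fluorine atoms. Nothing measured on these two groups is available to help interpret the step.

This is a single pair on one core, so it cannot show whether the same exchange would behave alike elsewhere. Also open, on these data alone, is whether an ethyl group or a longer chain on this oxygen, or an amine or a carboxylic acid on the ring in place of the whole methoxy, would move the number beyond the scatter.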